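Working notes: cyclopentyl in place of isopropyl

This account rests on a few compounds, and the source may have more. Where it says the series, first, only, none or still open, it means among the compounds named here.

In a functional assay on A549 cells (Homo sapiens) for cytotoxicity, read by MTT assay, with a stated time of 72 h (a lower number here means that less compound is needed, a higher number that more compound is needed for the effect), the measured compounds stand as follows:
compound 1 `COc1ccc(Nc2cc(C)oc(=O)c2)cc1`, a limit of the assay: > 30 uM
compound 2 `COc1ccc(Nc2cc(C(C)C)oc(=O)c2)cc1`, a limit of the assay: > 30 uM

Compound 2 sits at a limit of this assay and not at a number. Both values shown are such limits (the limit of > 30 uM in this assay, at which 2 of the 2 values shown sit). For the measured compounds named here, the only measured step, a step that the two limits leave unreadable from compound 1 to compound 2, is therefore unreadable in size; it exchanges methyl for isopropyl on an aromatic carbon and gives no footing for judging the next change.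

Compound 3 `COc1ccc(Nc2cc(C3CCCC3)oc(=O)c2)cc1` carries the change (cyclopentyl in place of isopropyl on an aromatic carbon). Going by the values given here, no measured step bears on it in a readable way, so no step beyond the scatter is expected in this assay in either direction, and a further limit is the most likely outcome. Compound 3 is estimated at 40 uM, with a range from 12 uM to 120 uM. This corresponds to an expected step that the limit leaves unreadable from compound 2 to compound 3.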

Compound 3, concentration for half-maximal effect: 5.42 uM
Beside the measured number, compound 3's estimate is 7.4-fold (0.87 log units) above it, outside the stated range (below it).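

Working notes: the position next to the ring oxygen can move the read-out in this assay, as cyclopentyl in place of isopropyl gives an at least 5.5-fold lower number from compound 2 to compound 3 (0.74 log units; beyond the scatter), and cyclopentyl in place of methyl gives an at least 5.5-fold lower number from compound 1 to compound 3 (0.74 log units; beyond the scatter). Among the compounds shown, only the cyclopentyl group, with its five-membered ring of carbon only, goes with a value that is a number rather than a limit. Both steps give only a minimum size and the step from methyl to isopropyl cannot be read, because the two smaller-group compounds sit at a limit: the limit of > 30 uM in this assay, at which 2 of the 3 values shown sit.

Whether the lower number goes with the ring itself or with the larger carbon count stays open, since no open-chain pentyl group is among the compounds shown. Also open, on these data alone, is how a cyclobutyl or cyclohexyl ring, or a ring carrying an amine, would read at this position.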